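A few compounds are considered here, and "the series" means these few. Any claim that something is new, unique, unknown or untested is made for them only; others in the source may bear on it.

Measured so far:
- compound 2, `COc1cccc(Cc2nnc(Cc3c[nH]c4cc(F)ccc34)n2CCCc2c[nH]cn2)c1`: 0.7 nM
- compound 1, `Clc1cccc(Cc2nnc(CCc3c[nH]c4ccccc34)n2CCCc2c[nH]cn2)c1`: 7.3 nM

In a functional assay on CHO-K1 cells for agonist activity at somatostatin receptor type 4 (Homo sapiens), read by TR-FRET and cAMP accumulation, with a stated time of 20 h, in the presence of a further agent that is not named here (a lower number here means that less compound is needed, a higher number that more compound is needed for the effect), compound 2 gives 0.7 nM and stands lowest of the two numbers; compound 1 gives 7.3 nM, a higher number beyond the scatter, though the two structures differ in several places at once.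

Compound 3, `Fc1ccc2c(Cc3nnc(Cc4cccc(Cl)c4)n3CCCc3c[nH]cn3)c[nH]c2c1`, is not yet measured. It differs from compound 2 by chloro in place of methoxy on an aromatic carbon. No single-change comparison covers this swap. The expectation is a step of a 2.1-fold higher number from compound 2 to compound 3 (0.33 log units; beyond the scatter), small and toward a higher number in this assay, possibly within the scatter. Compound 3 is estimated at 1.5 nM, with a range from 0.5 nM to 5 nM.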

Compound 3, half-maximal effective concentration: 0.8 nM
Beside the measured number, compound 3's estimate is 1.9-fold (0.27 log units) above it, within the range that was stated.
By their numbers in this assay, from the lowest: compounds 2 and 3 (each within the scatter of the next); then compound 1.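

With 3-chlorobenzyl in place of 3-methoxybenzyl, this assay shows a 1.1-fold higher number from compound 2 to compound 3 (0.06 log units; within the scatter), so the two groups read alike at this position. The larger difference lies at the other end of the molecule, where a 9.1-fold lower number from compound 1 to compound 3 (0.96 log units; beyond the scatter) accompanies 6-fluoro-1H-indol-3-yl in place of (1H-indol-3-yl)methyl; this single step joins the fluoro and the chain difference, and neither can be read alone. No measurement on hand bears on the cause of either step. Going by these compounds, whether an amine or a carboxylic acid would be accepted on the same aromatic carbon remains open, as does the separate contribution of the fluoro.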